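This account rests on a few compounds, and the source may have more. Where it says the series, first, only, none or still open, it means among the compounds named here.

Measured compounds in a functional assay on HEK293 cells for agonist activity at D(4) dopamine receptor (Homo sapiens), read by FLIPR; on this read-out higher numbers stand for larger maximal responses and lower numbers for smaller maximal responses:
compound 1 `Cc1cc(C(=O)NCN2CCC(c3cccc[n+]3[O-])CC2)ccc1F` gives 67%
compound 2 `CC(C)Oc1cccc(NC(=O)CN2CCC(c3cccc[n+]3[O-])CC2)c1` gives 48%
compound 3 `Cc1cccc(NC(=O)CN2CCC(c3ccccc3)CC2)c1` gives 37%

Among these three, compound 1 stands highest. Its nearest neighbour is compound 2, whose number lies lower by a gap beyond the usual scatter, and compound 3 lies further below, also beyond the scatter. No two of these compounds differ in only one place, so no single step between measured compounds can be read off.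

Compound 4 `C=Cc1cccc(C(=O)NCN2CCC(c3cccc[n+]3[O-])CC2)c1` has not yet been measured. It differs from compound 1 in one place: 3-vinylphenyl in place of 4-fluoro-3-methylphenyl on a carbonyl carbon. Among the compounds with values here, nothing among the measured compounds shows what such an exchange does to the maximal response, so the expectation rests on compound 1 alone. Because compound 1 gives 67% in this assay, the estimate for compound 4 starts from that number and is expected to move only a little, if at all, downward. The step of a number 7 percentage points lower from compound 1 to compound 4 (within the scatter) is expected to be small and may well stay within the scatter. Compound 4 is therefore expected to give about 60%, with a range from 42% to 76%.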

Compound 4, largest response reached (reported as efficacy), in percent of the reference or control that the assay uses: 63%
Beside the measured number, compound 4's estimate is 3 percentage points below it, within the range that was stated.
By their numbers in this assay, from the lowest: compound 3; then compound 2; then compounds 4 and 1 (each within the scatter of the next).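

In this assay, within the data shown here, putting 3-vinylphenyl in place of 4-fluoro-3-methylphenyl on a carbonyl carbon gives a number 4 percentage points lower from compound 1 to compound 4 (within the scatter), the first step that can be read at this position. The exchange removes the fluorine and the methyl and brings in a double bond outside the aromatic ring, yet the maximal responses of the two compounds cannot be told apart, so this one change leaves the read-out within its usual scatter. Nothing available explains why these two groups behave so alike.

As far as these compounds go, both groups are six-membered aromatic rings of carbon only, so the effect of a different kind of group here, such as an amine, a carboxylic acid or a pyridine ring, remains open. Also open, from the compounds shown here alone, is what the fluorine, the methyl or the vinyl contributes alone, since this single step exchanges them together.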